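The compounds below may be only part of what the source reports. "The series", "measured", "known", "first", "only" and "open" are said of these compounds alone.

Working notes on the acid ceramidase series.

Of the compounds shown here, three share a carbamoyl-substituted core and have been measured in an assay on HEK293 cells for inhibition of acid ceramidase (Homo sapiens), read by fluorescence, with stated times of 10 min and 3 h; a higher number here means a weaker inhibitor, a lower number a stronger inhibitor. Compound 1 `CCC(C)NC(=O)n1c(=O)oc2cc(C3CCN(C)CC3)ccc21` gives 2100 nM in this assay. Compound 2 `O=C(NCCCCc1ccccc1)n1c2c(oc1=O)CCN(Cc1ccccc1)C2` gives 436 nM, and compound 3 `CCOCCNC(=O)n1c(=O)oc2cc(-c3ccc(F)cc3)ccc21` gives 2300 nM. Compound 1 thus stands with the second highest number of the three; its value and that of compound 3 lie within the usual scatter of each other, while compound 2 shows a clearly lower number than compound 1, beyond the scatter.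

The next compound, compound 4 `CCCCCNC(=O)n1c(=O)oc2cc(C3CCN(C)CC3)ccc21`, has not yet been measured in this assay. It differs from compound 1 in one place: pentyl in place of sec-butyl on an amide-type nitrogen. Going by the values given here, no pair of measured compounds in the set differs by this kind of change alone, so the size of its effect is not known from the data.

The expected step from compound 1 to compound 4 is a 2.1-fold lower number from compound 1 to compound 4 (0.32 log units; beyond the scatter), a modest move towards a lower number, because compound 2 with its pentyl-like chain length gives 436 nM. Compound 4 is therefore estimated at 1000 nM in this assay. The expected range for compound 4 runs from 400 nM to 2500 nM.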

Compound 4, half-maximal inhibitory concentration: 396 nM
Compound 4: middle estimate off by 2.5-fold (0.40 log units), on the high side; the measured number lies below the stated range.
By their numbers in this assay, from the lowest: compounds 4 and 2 (each within the scatter of the next); then compounds 1 and 3 (each within the scatter of the next).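

In this assay, pentyl in place of sec-butyl on the amide-type nitrogen gives a 5.3-fold lower number from compound 1 to compound 4 (0.72 log units; beyond the scatter) with the rest of compound 1 unchanged. Going by these compounds alone, this is the first direct reading of this position, and it shows that the group on this nitrogen alone can move the number beyond the scatter. Nothing at hand accounts for the size of this step.

Because sec-butyl is branched and pentyl is not, and pentyl is also the longer group, this single step cannot separate chain length from branching, and butyl and hexyl on the core of compound 1 would be needed to tell them apart. From the compounds shown here alone, whether pentyl gives a similar step on the core of compound 3 also remains open.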